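Methyl to Ethyl on the Core: One Carbon Added

The compounds below may be only part of what the source reports. "The series", "measured", "known", "first", "only" and "open" are said of these compounds alone.

Measured so far:
compound 1 `COc1cccc(N2CCN(C(=O)c3oc(C)nc3-c3cccc(F)c3)CC2)c1` — "not active" (no number reported) in a functional assay on HL-60 cells (Homo sapiens) for inhibition, read by MTT assay, with a stated time of 72 h; a higher number here means a weaker inhibitor, a lower number a stronger inhibitor
compound 2 `COc1cccc(N2CCN(C(=O)c3oc(C)nc3-c3ccc(F)cc3)CC2)c1` — 112 nM

Compound 2 is the only compound here with a number; compound 1 has no number, only the note given above. Compound 3 `CCc1nc(-c2ccc(F)cc2)c(C(=O)N2CCN(c3cccc(OC)c3)CC2)o1` differs from compound 2 by methyl in place of hydrogen on a saturated chain carbon bound to an aromatic carbon — that is, methyl to ethyl. Going by the values given here, no measured pair in this set shows such a step, so its size is unknown; a small step, within the scatter, in either direction is expected. Compound 3 is therefore estimated at 120 nM (between 45 nM and 320 nM), an expected step of a 1.1-fold higher number from compound 2 to compound 3 (0.03 log units; within the scatter).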

Compound 3, half-maximal inhibitory concentration: 411 nM
Compound 3: the middle estimate sits 3.4-fold (0.53 log units) below what was measured; measured number above the stated range.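

In this assay, replacing methyl with ethyl gives a 3.7-fold higher number from compound 2 to compound 3 (0.56 log units; beyond the scatter). This shows that the position responds to a single added carbon: the new methyl, on a saturated chain carbon bound to an aromatic carbon, comes with a weaker inhibitor, and the step lies beyond the usual scatter. Nothing shown here explains why the number rises. The compounds shown leave open whether a longer chain such as propyl would continue this trend. They also leave open how an amine or a carboxylic acid at this position would compare.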